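From 3-methoxyphenyl to 4-methoxyphenyl: One Small Structural Swap

This account rests on a few compounds, and the source may have more. Where it says the series, first, only, none or still open, it means among the compounds named here.

- Compound 1 `COc1cc(O)cc(O)c1C(=O)/C=C/c1ccc(F)cc1`: 28800 nM
- Compound 2 `C=CCOc1cc(OC)c(C(=O)/C=C/c2cccc(OC)c2)c(OCC=C)c1`: 13100 nM

In a toxicity assay on cells (Macrophage, Mus musculus, strain BALB/c) for cytotoxicity, read by MTT assay (a higher number here means a weaker inhibitor, a lower number a stronger inhibitor), compound 2 gives 13100 nM, the lower of the two numbers and beyond the scatter of compound 1. These two compounds differ in more than one place, so their gap says little about any single change.

Compound 3 `C=CCOc1cc(OC)c(C(=O)/C=C/c2ccc(OC)cc2)c(OCC=C)c1` has the same atoms as compound 2, joined differently: 4-methoxyphenyl in place of 3-methoxyphenyl on a double-bonded chain carbon bound to a double-bonded chain carbon. For the measured compounds named here, no pair of measured compounds shows what this swap does, so there is no direct evidence for its size or direction. A small change in this assay, with nothing beyond the scatter, is the cautious expectation. The expected change is a 1.1-fold higher number from compound 2 to compound 3 (0.03 log units; within the scatter). The estimated value for compound 3 is 14000 nM, with an expected range from 6000 nM to 32000 nM.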

Compound 3, half-maximal inhibitory concentration: 18700 nM
The estimate for compound 3 lay 1.3-fold (0.13 log units) below the measured number; the measured number falls inside the stated range.
By their numbers in this assay, from the lowest: compounds 2, 3 and 1 (each within the scatter of the next, the first and the last beyond it).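

For the compounds shown here, this pair gives the first direct reading of this swap, because compound 2 and compound 3 differ in one place only. In this assay, placing 4-methoxyphenyl where 3-methoxyphenyl stood, on a double-bonded chain carbon bound to a double-bonded chain carbon, gives a 1.4-fold higher number from compound 2 to compound 3 (0.15 log units; within the scatter), so the two groups cannot be told apart at this position in this assay. Nothing measured here bears on what lies behind these numbers.

From the compounds shown here alone, both compounds carry a methoxyphenyl group at this position, so it remains open whether a different group there, such as an amine or a carboxylic acid on the ring, would shift the number beyond the scatter. Compound 1 differs from compound 2 in more than one place, so the contribution of each of those differences also remains unresolved.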